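The source may hold more compounds than are shown below. What is called first, only, known or untested is meant among the compounds shown, and "the series" means these compounds.

Compounds measured in an assay on isolated protein for displacement of a labelled ligand from 5-hydroxytryptamine receptor 6 (Homo sapiens); on this read-out higher numbers stand for weaker inhibition and lower numbers for stronger inhibition:
compound 1, `NC[C@@H]1CCCc2cc(S(=O)(=O)c3cn[nH]c3)ccc21`: 2 nM
compound 2, `NC[C@@H]1CCCc2cc(S(=O)(=O)c3c[nH]c4ccccc34)ccc21`: 0.0501 nM
compound 3, `O=S(=O)(c1cccc(F)c1)c1ccc2c(c1)CCC[C@H]2CN1CCCS1(=O)=O`: 31.6 nM

Compound 3 gives the highest of the three numbers: compound 1 sits well lower, and compound 2 lower still, both gaps beyond the scatter. Compound 4, `COCCNC[C@@H]1CCCc2cc(S(=O)(=O)c3cccc(F)c3)ccc21`, differs from compound 3 by a group of 5 heavy atoms (3 carbon, 1 nitrogen, 1 oxygen; no ring) in place of a group of 7 heavy atoms (3 carbon, 1 nitrogen, 2 oxygen, 1 sulfur; one five-membered non-aromatic ring with 2 hetero atoms), on a saturated chain carbon bound to a saturated ring carbon. Going by the values given here, no step between measured compounds speaks directly to this change. Compounds 1 and 2, which carry a free amine on that chain carbon, both give far lower numbers than compound 3, so a group with one hydrogen-bond donor and no ring at that place is expected to move compound 4 toward them. The expected step in this assay a 7.9-fold lower number from compound 3 to compound 4 (0.90 log units; beyond the scatter) is a fall beyond the scatter. For compound 4 the estimate is 4 nM, within 1 nM to 20 nM.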

Compound 4, inhibition constant: 0.251 nM
Beside the measured number, compound 4's estimate is 16-fold (1.20 log units) above it; the whole stated range lies above it.
By their numbers in this assay, from the lowest: compound 2; then compound 4; then compound 1; then compound 3.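

In this assay, exchanging the five-membered ring group on the saturated chain carbon for (2-methoxyethyl)amino gives a 130-fold lower number from compound 3 to compound 4 (2.10 log units; beyond the scatter), a large step with the rest of the molecule unchanged. This place alone therefore moves the read-out strongly, and it accepts a substituted amine without a ring. Nothing measured here explains the size of this step.

Going by these compounds alone, the single step cannot separate the gain of the hydrogen-bond donor from the loss of the ring or the sulfonyl group. Nor does it show what the methoxy oxygen contributes, which a simple ethylamino or open-chain sulfonamide group at this place could help resolve.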